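Phenyl for Ethyl on the Triazole Nitrogen

The source may hold more compounds than are shown below. What is called first, only, known or untested is meant among the compounds shown, and "the series" means these compounds.

Compound 1 `CCn1c(SCC(=O)Nc2ccc(/C(C)=N/O)cc2)nnc1-c1cc(OC)c(OC)c(OC)c1`: 70%
Compound 2 `CCn1c(SCC(=O)Nc2ccc(C(C)=O)cc2)nnc1-c1cc(OC)c(OC)c(OC)c1`: 54%

In a functional assay on the whole organism (strain albino) for inhibition, with Rattus norvegicus as the target, read by paw edema, with stated times of 30 min and 3 h, at a dose of 0.28 mmol/kg by the oral route (a lower number here means less inhibition, a higher number more inhibition at the dose given (going by the name of the read-out)), compound 1 gives 70% and compound 2 gives 54%. Compound 2 stands lowest of the two, with a number 16 percentage points lower from compound 1 to compound 2 (beyond the scatter). Compound 3 `COc1cc(-c2nnc(SCC(=O)Nc3ccc(C(C)=O)cc3)n2-c2ccccc2)cc(OC)c1OC` differs from compound 2 only in phenyl in place of ethyl on an aromatic nitrogen. For the measured compounds named here, no measured step touches that position, so none bears on it; the only known step concerns a different group. For compound 3 the expected change is therefore no change at the digits printed from compound 2 to compound 3 (within the scatter), none beyond the scatter. Compound 3 is estimated at 54%, within 36% to 70%.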

Compound 3, a percentage reported as inhibition, in the whole organism at one dose (the size of the read-out at that dose, not a potency): 55%
Compound 3: the middle estimate sits 1 percentage points below what was measured, and the stated range covers the measured number.
By their numbers in this assay, from the lowest: compounds 2 and 3 (each within the scatter of the next); then compound 1.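

In this assay, phenyl in place of ethyl on the aromatic nitrogen gives a number 1 percentage points higher from compound 2 to compound 3 (within the scatter). For the compounds shown here, this is the first reading at this position, and it does not separate the two groups: with the ketone in place, the nitrogen carries a six-membered aromatic ring or an ethyl group with no difference beyond the scatter. As far as these compounds go, how a longer chain such as butyl or a benzyl group would read here remains open, as does whether phenyl would read the same alongside the oxime of compound 1, and no measurement at hand offers an explanation for this result.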